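Swapping chloro for fluoro on the aromatic ring

The source may report more compounds than this note shows. Statements on the series, on what has been measured and on what is new or still open speak of the compounds shown alone.

Within the data shown here, compound 2, `COCCNc1ccc2ncc(-c3ccc(Cl)cc3)n2n1`, gives 1620 nM in an assay on isolated protein for inhibition of MAP kinase-interacting serine/threonine-protein kinase 1 (Homo sapiens) (on this read-out higher numbers stand for weaker inhibition and lower numbers for stronger inhibition), the lower of the two numbers measured so far; compound 1, `CNc1ccc2ncc(-c3ccc(F)cc3)n2n1`, gives 4050 nM, which is the higher number and lies beyond the usual scatter. Compound 3, `COCCNc1ccc2ncc(-c3ccc(F)cc3)n2n1`, is compound 2 with one change: fluoro in place of chloro on an aromatic carbon. Among the measured compounds shown here, no directly comparable step between measured compounds exists for this change. A small rise toward weaker inhibition is expected, with the step from a 1.5-fold higher number from compound 2 to compound 3 (0.19 log units; within the scatter) likely staying near the edge of the scatter. Compound 3 is therefore estimated at 2500 nM, within a range from 1200 nM to 5500 nM.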

Compound 3, half-maximal inhibitory concentration: 4090 nM
Compound 3: the middle estimate sits 1.6-fold (0.21 log units) below what was measured; measured number inside the range.
By their numbers in this assay, from the lowest: compound 2; then compounds 1 and 3 (each within the scatter of the next).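

In this assay the change from 4-chlorophenyl to 4-fluorophenyl gives a 2.5-fold higher number from compound 2 to compound 3 (0.40 log units; beyond the scatter) with the methoxyethyl side chain held fixed, so the halogen at this position does affect the read-out. With fluoro held fixed, methoxymethyl in place of hydrogen on the side chain gives a 1.0-fold higher number from compound 1 to compound 3 (0.00 log units; within the scatter), which leaves the two numbers within the scatter of each other. Nothing at hand explains either result.

On these data alone, it remains open how bromo, methyl or a nitrile would compare with chloro at this position. As far as these compounds go, it is also open whether chloro keeps its edge over fluoro with other side chains, such as one ending in an amine.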